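The compounds below may be only part of what the source reports. "The series", "measured", "known", "first", "only" and "open" are said of these compounds alone.

Values in an ADME assay on J774 cells (Mus musculus) for antiproliferative activity, with a stated time of 72 h; a higher number here means that more compound is needed for the effect, a lower number that less compound is needed:
Compound 1 `CCCCc1cc2c(=O)c(CC)c(C)[nH]c2cc1OCCOc1ccccc1`: 1000 nM
Compound 2 `CCCCc1cc2c(=O)c(-c3ccncc3)c(C)[nH]c2cc1OCCOc1ccccc1`: 23000 nM
Compound 3 `CCCCc1cc2c(=O)c(-c3ccc(C(F)(F)F)cc3C)c(C)[nH]c2cc1OCCOc1ccccc1`: 20000 nM

Compound 3, at 20000 nM, cannot be told apart from compound 2, since the gap between them is a 1.2-fold lower number from compound 2 to compound 3 (0.06 log units; within the scatter). Both stand well clear of the ethyl compound. The two large steps are a 23-fold higher number from compound 1 to compound 2 (1.36 log units; beyond the scatter), and a 20-fold higher number from compound 1 to compound 3 (1.30 log units; beyond the scatter).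

The next compound, compound 4 `CCCCc1cc2c(=O)c(-c3ccc(Cl)cc3C)c(C)[nH]c2cc1OCCOc1ccccc1`, differs from compound 3 in one place: chloro in place of trifluoromethyl on an aromatic carbon. This puts chloro in place of trifluoromethyl on an aromatic carbon, turning 2-methyl-4-(trifluoromethyl)phenyl into 4-chloro-2-methylphenyl.

For the measured compounds named here, no measured step makes this exact exchange. The two large steps both remove ethyl, which compound 4 does not do, so they offer no direct guide. The closest evidence is compound 3 itself, reached from compound 2 by a swap of the whole ring group with a 1.2-fold lower number from compound 2 to compound 3 (0.06 log units; within the scatter). Going by the values given here, a smaller edit on that ring is therefore expected to give no step beyond the scatter in this assay, though this rests on only one such comparison. The estimated step is a 1.3-fold lower number from compound 3 to compound 4 (0.10 log units; within the scatter). For compound 4 the expected value is 16000 nM. Its estimated range runs from 7000 nM to 32000 nM.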

Compound 4, half-maximal effective concentration: > 21000 nM
Compound 4: a limit, no number; the forecaster's own chance of this, stated with the estimate: 10%; middle value at least 1.3-fold (0.11 log units) away from the limit.
By their numbers in this assay, from the lowest: compound 1; then compounds 3 and 2 (each within the scatter of the next).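

In this assay compound 4 gives no number, only a limit of the assay: the limit of > 21000 nM in this assay, at which 1 of the 4 values shown sits. Chloro in place of trifluoromethyl, on the carbon meta to a methyl group and para to a large group, gives an at least 1.0-fold higher number from compound 3 to compound 4 (0.02 log units; that floor lies within the scatter), so the floor of this step does not separate the two compounds, and the steps that the limit leaves unreadable cannot be used. Against the ethyl compound the reading is clearer, with an at least 21-fold higher number from compound 1 to compound 4 (1.32 log units; beyond the scatter), so 4-chloro-2-methylphenyl joins pyridin-4-yl and 2-methyl-4-(trifluoromethyl)phenyl as a third ring group in place of ethyl that gives a large step, and no compound shown goes against this.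

From the compounds shown here alone, how far compound 4 really lies past its limit stays open, and with it whether chloro and trifluoromethyl differ at all at this place on the ring. Also open, going by these compounds, is whether an amine or a carboxylic acid on that phenyl ring, or a longer chain such as propyl in place of ethyl, would stay near compound 1 or move towards the three ring compounds.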